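This account rests on a few compounds, and the source may have more. Where it says the series, first, only, none or still open, it means among the compounds named here.

Two compounds share one core and differ only in the aromatic ring that sits on a saturated chain carbon, two bonds along the chain from a saturated ring carbon. Compound 1 `Cc1cc(SC2=C(O)OC(CCc3nccs3)(C(C)C)CC2=O)c(C(C)(C)C)cc1CO` in an in vivo ADME assay on the whole organism for pharmacokinetics (a lower number here means that the compound disappears faster, a higher number that the compound lasts longer), gives 12.2 h. Compound 2 `Cc1cc(SC2=C(O)OC(CCc3scnc3C)(C(C)C)CC2=O)c(C(C)(C)C)cc1CO` in this assay gives 12.2 h, so the step of no change at the digits printed from compound 1 to compound 2 (within the scatter) stays within the scatter. Compound 2 thus stands level with compound 1 on the numbers in hand, and neither can be ordered above the other.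

The next compound, compound 3 `Cc1cc(SC2=C(O)OC(CCc3ccsc3)(C(C)C)CC2=O)c(C(C)(C)C)cc1CO`, carries yet another ring in the same place: thiophen-3-yl in place of 4-methyl-1,3-thiazol-5-yl on a saturated chain carbon, two bonds along the chain from a saturated ring carbon. Among the measured compounds shown here, the only measured step that bears on this change is the exchange of one five-membered aromatic ring for another there, no change at the digits printed from compound 1 to compound 2 (within the scatter), which moved nothing beyond the scatter. A single step is a thin basis, and the entering ring holds one hetero atom where the leaving ring held two, but nothing in hand points in either direction. The step is therefore expected to be small, a 1.0-fold lower number from compound 2 to compound 3 (0.01 log units; within the scatter), with no change beyond the scatter in this assay. For compound 3 the estimate is 12 h, between 7 h and 20 h.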

Compound 3, half-life: 9.4 h
Beside the measured number, compound 3's estimate is 1.3-fold (0.11 log units) above it, and the stated range covers the measured number.
By their numbers in this assay, from the lowest: compounds 3, 1 and 2 (each within the scatter of the next).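

The exchange of rings gives a 1.3-fold lower number from compound 2 to compound 3 (0.11 log units; within the scatter) in this assay and, measured against the other thiazole, a 1.3-fold lower number from compound 1 to compound 3 (0.11 log units; within the scatter). The earlier pair had only compared two rings with 2 hetero atoms each, whereas thiophen-3-yl has one five-membered aromatic ring with 1 hetero atom and 1 hydrogen-bond acceptor, and no nitrogen or methyl group, and still no step beyond the scatter appears at this saturated chain carbon. The three compounds therefore show that, in this series, this place accepts these three rings with no readable difference in half-life, while the data offer no account of what underlies the numbers.

The compounds shown leave open whether this insensitivity extends beyond five-membered aromatic rings, for instance to a phenyl or pyridine ring, or to a group of another kind, such as an amine or a carboxylic acid, at the end of the chain. They also leave open whether a longer chain carrying the same thiophen-3-yl ring would behave the same way in this assay.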